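A few compounds are considered here, and "the series" means these few. Any claim that something is new, unique, unknown or untested is made for them only; others in the source may bear on it.

Compound 1 `CNc1nc(NCc2ccc(Cl)cc2Cl)cc(-c2ccccn2)n1` gives the lowest number of the three measured compounds in a functional assay on HEK293 cells for agonist activity at G-protein coupled receptor 39 (Mus musculus), read by inositol phosphate accumulation (a lower number here means that less compound is needed, a higher number that more compound is needed for the effect), at 0.5 nM. Compound 2 `CNc1nc(NCc2ccc(NC(C)=O)cc2)cc(-c2ccccn2)n1` gives 2 nM in this assay, and compound 3 `CNc1nc(NCc2ccc(NS(C)(=O)=O)cc2)cc(-c2ccccn2)n1` gives 8 nM. Going by the values given here, the single measured step, a 4.0-fold higher number from compound 2 to compound 3 (0.60 log units; beyond the scatter), concerns a different group and leaves the site changed here untouched. Compound 4 `CNc1nc(NCc2ccncc2)cc(-c2ccccn2)n1` differs from compound 1 by pyridin-4-yl in place of 2,4-dichlorophenyl on a saturated chain carbon bound to a nitrogen on an aromatic ring. Among the compounds with values here, no measured pair exchanges that ring itself, so the measured step offers no direct guide; still, compound 1 against compound 2 and compound 3 shows that changes on that ring move this assay beyond the scatter. Compound 4 is therefore expected to give a higher number, estimated at 20 nM with a range from 4 nM to 100 nM, a step of a 40-fold higher number from compound 1 to compound 4 (1.60 log units; beyond the scatter).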

Compound 4, half-maximal effective concentration: 304 nM
For compound 4 the middle estimate is 15-fold (1.18 log units) below the measured one; measured number outside the range, above it.
By their numbers in this assay, from the lowest: compound 1; then compound 2; then compound 3; then compound 4.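

Replacing 2,4-dichlorophenyl with pyridin-4-yl changes the ring itself on the saturated chain carbon, and a 610-fold higher number from compound 1 to compound 4 (2.78 log units; beyond the scatter) in this assay is a large step. A six-membered aromatic ring at this place is therefore not enough to keep the low number of compound 1. No measurement shown explains the size of this step.

The compounds shown leave open whether the step follows the ring nitrogen or the absence of both chlorine atoms. An unsubstituted phenyl ring at this place would separate the two.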